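A Cyano Swap at the Assay Limit

A few compounds are considered here, and "the series" means these few. Any claim that something is new, unique, unknown or untested is made for them only; others in the source may bear on it.

In a functional assay on SEM cells (Homo sapiens) for cytotoxicity, with a stated time of 72 h (a higher number here means that more compound is needed for the effect, a lower number that less compound is needed), compound 1 `C=C[C@@](C)(/C=C/c1ccc(O)cc1)CCC=O` gives > 36600 nM, which is a limit of the assay and not a number. Compound 2 `C=C[C@@](C)(/C=C/c1ccc(O)cc1)CCCO` gives > 36600 nM, also a limit. Compound 3 `C=C[C@@](C)(/C=C/c1ccc(O)cc1)CC/C=C/C(=O)c1ccccc1` gives > 36600 nM, a limit once more. Compound 3 therefore has no measured number and stands level with the other two, as the summary shows: the limit of > 36600 nM in this assay, at which 3 of the 3 values shown sit.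

The next structure, compound 4 `C=C[C@@](C)(/C=C/c1ccc(O)cc1)CC/C=C/C#N`, carries cyano in place of benzoyl on a double-bonded chain carbon bound to a double-bonded chain carbon. Going by the values given here, only one measured step changes a single place, a step that the two limits leave unreadable from compound 1 to compound 2. That step swaps formyl for hydroxymethyl, not the group changed here, and it offers no size to carry over. Compound 3 itself gives only a limit, so the starting point for the new step is not a true number either.

No clear change in either direction can therefore be predicted, and the expected move is a step that the limit leaves unreadable from compound 3 to compound 4. For compound 4 the estimate is 40000 nM, with an expected range from 12000 nM to 80000 nM, and the assay will probably report only a limit again.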

Compound 4, half-maximal effective concentration: > 36600 nM
Compound 4: no number, only a limit (the forecaster's own chance of this, stated with the estimate: 75%); the middle value is on the limit's open side.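

In this assay compound 4 gives > 36600 nM and this is a limit, not a number. Its steps from compound 1, compound 2 and compound 3 therefore cannot be read, since all four compounds share that limit: the limit of > 36600 nM in this assay, at which 4 of the 4 values shown sit.

The compounds shown leave open what true value any of them has in this assay and how much any of these swaps changes it.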